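Swapping Isopropyl for Phenyl on a Urea Nitrogen

A few compounds are considered here, and "the series" means these few. Any claim that something is new, unique, unknown or untested is made for them only; others in the source may bear on it.

Compound 1 `CC(C)NC(=O)NC1CC(C)(C)Oc2ccc(Cl)cc21` is a urea built on a bicyclic core. In a functional assay on U-373MG ATCC cells (Homo sapiens) for inhibition, read by MTT assay, with a stated time of 72 h (a lower number here means a stronger inhibitor, a higher number a weaker inhibitor), compound 1 gives 62000 nM, the highest of the three numbers at hand, although compound 2 `O=[N+]([O-])c1cccc(NC(=S)NCc2cccc(Cl)c2)c1`, at 32000 nM, lies within the scatter of it. Compound 3 `CC1(C)CC(NC(=O)Nc2ccc(Cl)cc2)c2cc(Br)ccc2O1`, built on a closely related core, gives 25000 nM, a gap from compound 1 that is beyond the scatter. Compound 4 `CC1(C)CC(NC(=O)Nc2ccccc2)c2cc(Cl)ccc2O1` differs from compound 1 by a single change: phenyl in place of isopropyl on an amide-type nitrogen. Among the compounds with values here, no measured pair shows exactly this step, so compound 3 is the nearest guide. The step of a 1.8-fold lower number from compound 1 to compound 4 (0.25 log units; within the scatter) is expected to lower the number by roughly the edge of the scatter. Compound 4 is estimated at 35000 nM, within a range from 12000 nM to 100000 nM.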

Compound 4, half-maximal inhibitory concentration: 68000 nM
Estimate against measurement, compound 4: 1.9-fold (0.29 log units) below; measured number inside the range.
By their numbers in this assay, from the lowest: compounds 3, 2, 1 and 4 (each within the scatter of the next, the first and the last beyond it).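

In this assay, the swap from isopropyl to phenyl reads as a 1.1-fold higher number from compound 1 to compound 4 (0.04 log units; within the scatter), so the two groups cannot be told apart on this amide-type nitrogen. Within the data shown here, this is the first measured step at this position, and the larger group, with its six-membered aromatic ring, leaves the read-out within the scatter. Nothing measured here offers an explanation for this result. Still open, from the compounds shown here alone, is whether a longer chain ending in an amine or a carboxylic acid on this nitrogen would give a step beyond the scatter.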